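Swapping the Benzyl Substituent in an Alpha-1B Antagonist Series

The compounds below may be only part of what the source reports. "The series", "measured", "known", "first", "only" and "open" are said of these compounds alone.

Compound 1, `COc1cccc(OC)c1OCCNCCOc1ccccc1OCc1ccccc1[N+](=O)[O-]`: 8.56
Compound 2, `COc1cccc(COc2ccccc2OCCNCCOc2c(OC)cccc2OC)c1`: 8.31

In a functional assay on spleen for antagonist activity at Alpha-1B adrenergic receptor (Rattus norvegicus) (a higher number here means a more potent compound, by a factor of ten per unit of this negative logarithm, a lower number a less potent compound), compound 1 gives 8.56 and compound 2 gives 8.31. Compound 2 cannot be told apart from compound 1, since the step of a number 0.25 log units lower from compound 1 to compound 2 (within the scatter) lies within the scatter.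

Compound 3, `CCOc1ccc(COc2ccccc2OCCNCCOc2c(OC)cccc2OC)cc1`, differs from compound 2 by 4-ethoxyphenyl in place of 3-methoxyphenyl on a saturated chain carbon bound to an oxygen on an aromatic ring. Among the measured compounds shown here, the only measured step bearing on this, a number 0.25 log units lower from compound 1 to compound 2 (within the scatter), also changed the group at this place and stayed within the scatter, so no step beyond the scatter is expected in this assay. Compound 3 is therefore estimated at 8.2, between 7.6 and 8.8. The implied step a number 0.11 log units lower from compound 2 to compound 3 (within the scatter) is expected to stay inside the scatter.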

Compound 3, negative logarithm of the antagonist equilibrium constant: 8.23
For compound 3 the middle estimate is 0.03 log units below the measured one; the range from low to high includes it.
By their numbers in this assay, from the lowest: compounds 3, 2 and 1 (each within the scatter of the next, the first and the last beyond it).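

In this assay, exchanging 3-methoxyphenyl for 4-ethoxyphenyl, with its one extra heavy atom, gives a number 0.08 log units lower from compound 2 to compound 3 (within the scatter), so this position tolerates that change. Among the compounds shown here, exchanging 2-nitrophenyl for 4-ethoxyphenyl gives a number 0.33 log units lower from compound 1 to compound 3 (beyond the scatter), the first step at this position to pass the scatter, though only modestly. Nothing measured here offers an explanation for these numbers. All three groups shown are substituted phenyl rings, so the effect of a carboxylic acid or an amine on that ring stays open. As far as these compounds go, whether a plain phenyl or a pyridine ring would hold these numbers also stays open.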